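Methoxy on the fused ring of the carboxymethyl rhodanine series

A few compounds are considered here, and "the series" means these few. Any claim that something is new, unique, unknown or untested is made for them only; others in the source may bear on it.

Measured compounds in a functional assay on A549 cells (Homo sapiens) for antiproliferative activity, read by MTT assay, with a stated time of 72 h; on this read-out lower numbers stand for stronger inhibition and higher numbers for weaker inhibition:
compound 1 `O=C1NC(=S)S/C1=C\C1=Cc2ccccc2OC1` gives 73100 nM
compound 2 `O=C(O)CN1C(=O)/C(=C/C2=Cc3ccccc3OC2)SC1=S` gives > 100000 nM
compound 3 `O=C(O)CN1C(=O)/C(=C/C2=Cc3cc(Br)ccc3OC2)SC1=S` gives > 25000 nM

Compound 2 stands at a limit of this assay; its value is a limit and not a number, recorded as the limit of > 100000 nM in this assay, at which 1 of the 3 values shown sits. Compound 3 likewise stands only at a limit, (the limit of > 25000 nM in this assay, at which 1 of the 3 values shown sits). For the measured compounds named here, compound 1 is the sole compound with a definite number.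

Compound 4 `COc1cccc2c1OCC(/C=C1\SC(=S)N(CC(=O)O)C1=O)=C2` differs from compound 2 by methoxy in place of hydrogen on an aromatic carbon. Two measured steps are on hand. The step of an at least 1.3-fold higher number from compound 1 to compound 2 (0.13 log units; that floor lies within the scatter) adds the carboxymethyl that compound 4 shares with compound 2 and is weak. The step that the two limits leave unreadable from compound 2 to compound 3 is the only aromatic substitution measured and cannot be read from its two limits; it therefore neither supports nor contradicts any direction for a methoxy at the same kind of position.

With compound 2 itself only a limit, the expected step of a number no higher from compound 2 to compound 4 (the limit leaves the size open) is none beyond the scatter. Compound 4 is estimated at 100000 nM, within 30000 nM to 300000 nM, with a substantial chance that this assay again reports only a limit.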

Compound 4, half-maximal inhibitory concentration: > 200000 nM
Compound 4 ended at the assay's limit (the forecaster's own chance of this, stated with the estimate: 70%); at least 2.0-fold (0.30 log units) between middle value and limit.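

In this assay compound 4 gives > 200000 nM, a limit and not a number. For the compounds shown here, compound 2 gives > 100000 nM, likewise a limit, and no step between compound 2 and compound 4 can be read. On these data alone, whether methoxy in place of hydrogen on an aromatic carbon changes the value, and in which direction, stays open.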